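Pyrazole for fluoropyridine on the oxygen-containing core

The compounds below may be only part of what the source reports. "The series", "measured", "known", "first", "only" and "open" are said of these compounds alone.

Of the compounds shown here, two have been measured in an ADME assay on the whole organism (Mus musculus, strain BALB/c) for pharmacokinetics, read by LC-MS, with a stated time of 24 h, at a dose of 10 mg/kg by the oral route; on this read-out lower numbers stand for lower exposure and higher numbers for higher exposure at the dose given. Compound 1 `Cn1nccc1-c1cc(C(F)(F)F)ccc1[C@H]1CCc2cc(S(=O)(=O)Nc3ncccn3)ccc21` gives 18000 nM in this assay. Compound 2 `O=S(=O)(Nc1ncccn1)c1ccc2c(c1)OCC[C@@H]2c1ccc(C(F)(F)F)cc1-c1ccc(F)nc1` gives 17000 nM in this assay; its number sits within the scatter of the number for compound 1, so the two are not told apart on this read-out. Among the compounds with values here, no step between measured compounds that differ in one place is available.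

Compound 3 `Cn1nccc1-c1cc(C(F)(F)F)ccc1[C@H]1CCOc2cc(S(=O)(=O)Nc3ncccn3)ccc21` is not yet measured. It differs from compound 2 by 1-methyl-1H-pyrazol-5-yl in place of 6-fluoropyridin-3-yl on an aromatic carbon. Within the data shown here, the same pyrazole is carried by compound 1, and compound 1 and compound 2 give numbers within the scatter of each other, which is the only guidance available. The step from compound 2 to compound 3 is therefore expected to be no change at the digits printed from compound 2 to compound 3 (within the scatter), not beyond the scatter in either direction. Compound 3 is estimated at 17000 nM in this assay, with a range from 8000 nM to 36000 nM.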

Compound 3, maximal plasma concentration: 15000 nM
Estimate against measurement, compound 3: 1.1-fold (0.05 log units) above, and the stated range covers the measured number.
By their numbers in this assay, from the lowest: compounds 3, 2 and 1 (each within the scatter of the next).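

In this assay the change to 1-methyl-1H-pyrazol-5-yl in place of 6-fluoropyridin-3-yl on this aromatic carbon, ortho to a large group and meta to a trifluoromethyl group, reads as a 1.1-fold lower number from compound 2 to compound 3 (0.05 log units; within the scatter) and gives the series its first comparison of compounds that differ in one place. On the core shared by compound 2 and compound 3, the two groups are therefore not told apart by maximal plasma concentration. Nothing at hand explains this result.

On these data alone, whether an amine or a carboxylic acid on the same aromatic carbon would give a step beyond the scatter remains open. Also open, as far as these compounds go, is whether 6-fluoropyridin-3-yl on the core of compound 1 would leave the number within the scatter of compound 1.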